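A few compounds are considered here, and "the series" means these few. Any claim that something is new, unique, unknown or untested is made for them only; others in the source may bear on it.

Of the compounds shown here, three sharing one core have been measured in an assay for inhibition of serine/threonine-protein kinase Sgk1 (Homo sapiens), with stated times of 30 min and 60 min, in the presence of a further agent that is not named here; on this read-out higher numbers stand for weaker inhibition and lower numbers for stronger inhibition. Compound 1 `CNC(=O)c1cc(-c2ccc(NS(=O)(=O)c3cccc(Cl)c3Cl)cc2)nc2[nH]ncc12` gives 929 nM. Compound 2 `CC(C)NC(=O)c1cc(-c2ccc(NS(=O)(=O)c3cccc(Cl)c3Cl)cc2)nc2[nH]ncc12` gives 17600 nM. Compound 3 `CN(C)CCCNC(=O)c1cc(-c2ccc(NS(=O)(=O)c3cccc(Cl)c3Cl)cc2)nc2[nH]ncc12` gives 633 nM, the lowest of the three numbers, though its gap to compound 1 lies within the scatter, while its gap to compound 2 is large.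

Compound 4 `CCN1CCC(CNC(=O)c2cc(-c3ccc(NS(=O)(=O)c4cccc(Cl)c4Cl)cc3)nc3[nH]ncc23)C1` has not yet been measured. It differs from compound 3 in that (1-ethylpyrrolidin-3-yl in place of 2-(dimethylamino)ethyl on a saturated chain carbon bound to an amide-type nitrogen).

Among the measured compounds shown here, two measured steps bear on this. The change a 1.5-fold lower number from compound 1 to compound 3 (0.17 log units; within the scatter) shows that extending the methyl amide into a longer chain carrying a dimethylamino group left the number essentially unchanged. The change a 19-fold higher number from compound 1 to compound 2 (1.28 log units; beyond the scatter) shows that a more branched substituent on the amide-type nitrogen raised the number sharply, and a 28-fold lower number from compound 2 to compound 3 (1.44 log units; beyond the scatter) reversed it. Compound 4 keeps a chain carbon bound to the amide-type nitrogen but replaces the open chain by a ring, so a modest weakening, if any, is expected: a 1.6-fold higher number from compound 3 to compound 4 (0.20 log units; within the scatter). Compound 4 is therefore estimated at 1000 nM, with a range from 300 nM to 3500 nM.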

Compound 4, half-maximal inhibitory concentration: 109 nM
The estimate for compound 4 lay 9.2-fold (0.96 log units) above the measured number; measured number outside the range, below it.
By their numbers in this assay, from the lowest: compound 4; then compounds 3 and 1 (each within the scatter of the next); then compound 2.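

In this assay, the position on a saturated chain carbon bound to an amide-type nitrogen accepted a group with one five-membered non-aromatic ring and gave a clear further drop: 1-ethylpyrrolidin-3-yl in place of 2-(dimethylamino)ethyl produced a 5.8-fold lower number from compound 3 to compound 4 (0.76 log units; beyond the scatter), whereas the open chain of compound 3 had stayed within the scatter of compound 1. The new group also stands clear of the methyl amide, with an 8.5-fold lower number from compound 1 to compound 4 (0.93 log units; beyond the scatter), and of the isopropyl amide, with a 160-fold lower number from compound 2 to compound 4 (2.21 log units; beyond the scatter), so substituent size alone does not order these compounds, and compound 2 goes against any such trend. No measurement here accounts for the lower number of compound 4.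

The compounds shown leave open whether the ring itself or the ethyl on its nitrogen carries this step. A 1-methylpyrrolidin-3-yl, a piperidine ring or a cyclopentyl group at this place would bear on that question.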